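The source may report more compounds than this note shows. Statements on the series, on what has been measured and on what is new or still open speak of the compounds shown alone.

Values in a functional assay on COLO 205 cells (Homo sapiens) for inhibition; on this read-out lower numbers stand for stronger inhibition of growth and higher numbers for weaker inhibition of growth:
- Compound 1 `O=C(/C=C/c1cccc(O)c1)c1cccc(-n2cc(-c3ccccc3)[nH]c2=O)c1`: 2010 nM
- Compound 2 `O=C(/C=C/c1cccc(O)c1)c1cccc(-n2cc(-c3ccc(Cl)cc3)[nH]c2=O)c1`: 2290 nM
- Compound 3 `COc1cc(/C=C/C(=O)c2cccc(-n3cc(-c4ccc(Cl)cc4)[nH]c3=O)c2)ccc1O`: not yet measured

Compound 2 stands level with compound 1 within the scatter. The change to compound 3 is 4-hydroxy-3-methoxyphenyl in place of 3-hydroxyphenyl on a double-bonded chain carbon bound to a double-bonded chain carbon. Going by the values given here, the only measured step, a 1.1-fold higher number from compound 1 to compound 2 (0.06 log units; within the scatter), belongs to chloro in place of hydrogen on an aromatic carbon, a different change, and it gives no direction here. No step beyond the scatter is therefore expected in this assay. The expected step is a 1.3-fold lower number from compound 2 to compound 3 (0.10 log units; within the scatter). The estimate for compound 3 is 1800 nM, with an expected range from 600 nM to 5000 nM.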

Compound 3, concentration for 50% growth inhibition: 3400 nM
The estimate for compound 3 lay 1.9-fold (0.28 log units) below the measured number; measured number inside the range.
By their numbers in this assay, from the lowest: compounds 1, 2 and 3 (each within the scatter of the next).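

In this assay, going by these compounds alone, the first change at this position, 4-hydroxy-3-methoxyphenyl in place of 3-hydroxyphenyl on a double-bonded chain carbon bound to a double-bonded chain carbon, gives a 1.5-fold higher number from compound 2 to compound 3 (0.17 log units; within the scatter). This position therefore tolerates this exchange of aryl groups, with no step beyond the scatter. Nothing at hand bears on the reason for this result.

On these data alone, it remains open whether an aminophenyl or carboxyphenyl group at this place would give a step beyond the scatter. The shown compounds also leave open whether 4-hydroxy-3-methoxyphenyl behaves alike without the chloro group of compound 2.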